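Notes on trifluoromethyl-to-methyl changes in compounds 1 to 4

The compounds below may be only part of what the source reports. "The series", "measured", "known", "first", "only" and "open" are said of these compounds alone.

Measured compounds:
compound 1 `Nc1nc2ccc(C(F)(F)F)cn2c1-c1ccc(O)cc1`: > 100000 nM
compound 2 `Nc1nc2c(C(F)(F)F)cccn2c1-c1ccc(O)cc1`: > 100000 nM
compound 3 `Cc1ccc2nc(N)c(-c3ccc(O)cc3)n2c1`: > 100000 nM

In an assay on isolated protein for inhibition of ubiquitin carboxyl-terminal hydrolase 1 (Homo sapiens) (on this read-out higher numbers stand for weaker inhibition and lower numbers for stronger inhibition), compound 1 gives > 100000 nM, which is a limit of the assay and not a number. Compound 2 likewise gives only a limit, > 100000 nM. Compound 3 also gives only a limit, > 100000 nM. Compound 1 and compound 2 have the same atoms joined differently; the difference between the two cores is not broken down here.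

From compound 1 to compound 3 the change is methyl in place of trifluoromethyl on an aromatic carbon. The measured step is a step that the two limits leave unreadable from compound 1 to compound 3, and it stays unreadable because of the limit of > 100000 nM in this assay, at which 3 of the 3 values shown sit.

Compound 4 `Cc1cccn2c(-c3ccc(O)cc3)c(N)nc12` is not yet measured in this assay. It differs from compound 2 by methyl in place of trifluoromethyl on an aromatic carbon. The place is not the same as from compound 1 to compound 3: here it is ortho to a fused ring, there para to a fused ring, so this is the same kind of change, not the same change.

In this assay the step expected from compound 2 to compound 4 is a number no higher from compound 2 to compound 4 (the limit leaves the size open). That expectation rests on (the limit of > 100000 nM in this assay, at which 3 of the 3 values shown sit). Compound 4 is estimated at 100000 nM, between 30000 nM and 300000 nM, and most likely the assay will again report only a limit.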

Compound 4, half-maximal inhibitory concentration: > 100000 nM
Compound 4 gave a limit, no number (the forecaster's own chance of this, stated with the estimate: 85%); the middle value lies on the limit itself.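

In this assay compound 4 gives > 100000 nM, a limit of the assay and not a number. Compound 2 also stands at a limit, so no step can be read from compound 2 to compound 4: the limit of > 100000 nM in this assay, at which 4 of the 4 values shown sit.

The compounds shown leave open how trifluoromethyl and methyl compare at either place on the shared core.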